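The source may hold more compounds than are shown below. What is called first, only, known or untested is meant among the compounds shown, and "the series" means these compounds.

Compound 1, `CCOC(=O)C1=C(C)NC(=S)NC1c1cn(C(=O)CNc2ccccc2)c2ccccc12`, carries a thiourea core and an unsubstituted phenyl on the amine nitrogen. In a physicochemical assay for lipophilicity (on this read-out lower numbers stand for lower lipophilicity and higher numbers for higher lipophilicity), compound 1 gives 2.92, the highest of the three numbers in this set, standing beyond the scatter above both of its companions. Compound 2, `CCOC(=O)C1=C(C)NC(=O)NC1c1cn(C(=O)CNc2ccc([N+](=O)[O-])cc2Cl)c2ccccc12`, with the urea core and a 2-chloro-4-nitrophenyl, gives 1.99 in this assay. Compound 3, `CCOC(=O)C1=C(C)NC(=O)NC1c1cn(C(=O)CNc2ccc(Cl)cc2)c2ccccc12`, with the same urea core and a 4-chlorophenyl, gives 2.04. Going by the values given here, the one step that can be followed between measured compounds, a number 0.05 log units higher from compound 2 to compound 3 (within the scatter), shows that exchanging those two aryl groups leaves the read-out where it was.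

Compound 4, `CCOC(=O)C1=C(C)NC(=S)NC1c1cn(C(=O)CNc2ccccc2N)c2ccccc12`, differs from compound 1 in one place: amino in place of hydrogen on an aromatic carbon. Among the compounds with values here, none of the measured compounds carries an amino on its aryl group, so no measured step speaks directly to this change; the step between compound 2 and compound 3 concerns other groups on a different core and says nothing about an added amino. The expectation for compound 4 therefore rests on the general behaviour of this assay, where an added donor-acceptor group of this kind usually lowers the number. The estimated step is a number 0.82 log units lower from compound 1 to compound 4 (beyond the scatter). Compound 4 is expected to give 2.1, somewhere between 1.5 and 2.7.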

Compound 4, partition coefficient: 2.14
Compound 4: the middle estimate sits 0.04 log units below what was measured; the measured number falls inside the stated range.
By their numbers in this assay, from the lowest: compounds 2, 3 and 4 (each within the scatter of the next); then compound 1.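

In this assay, the change from phenyl to 2-aminophenyl is the first single change shown on the core of compound 1, and it comes to a number 0.78 log units lower from compound 1 to compound 4 (beyond the scatter) for the one heavy atom that enters. Going by these compounds alone, it shows that the number responds to what this aromatic carbon, ortho to a large group, carries, whereas the only earlier step, on the core of compound 3 and in another exchange of aryl groups, was a number 0.05 log units higher from compound 2 to compound 3 (within the scatter) and stayed within the scatter. Nothing measured here accounts for the size or direction of the new step, so it stands as an observation about this one pair and has no explanation behind it.

Whether the step belongs to amino alone remains open, since the compounds shown do not tell how a hydroxyl, a methoxy, a dimethylamino or a carboxylic acid on the same aromatic carbon would read. On these data alone, it is also open whether amino would move the number by a similar amount on the core of compound 3, with its carbonyl in the place of the thiocarbonyl of compound 1.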